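Compound 3: Swapping Cyclopropylamino for Cyclopentylamino

This account rests on a few compounds, and the source may have more. Where it says the series, first, only, none or still open, it means among the compounds named here.

Values so far in an ADME assay on Vero cells (Chlorocebus sabaeus) for cytotoxicity, read by CellTiter-Glo, with a stated time of 72 h; on this read-out lower numbers stand for higher toxicity in this test and higher numbers for lower toxicity in this test
Compound 1 `[O-][n+]1nc(NC2CCCC2)[n+]([O-])c2ccccc21` gives 10 ug/mL
Compound 2 `[O-][n+]1nc(NC2CC2)[n+]([O-])c2ccc(F)cc21` gives 1.3 ug/mL

Compound 2 holds the lower of the two numbers, which means the higher toxicity in this test. The change to compound 3 `[O-][n+]1nc(NC2CCCC2)[n+]([O-])c2ccc(F)cc21` is cyclopentyl in place of cyclopropyl on a nitrogen on an aromatic ring with cyclopentyl in place of cyclopropyl on a nitrogen on an aromatic ring. Going by the values given here, no measured pair shows this change alone. Compound 1, which also carries cyclopentylamino, gives 10 ug/mL and this points to a higher number. The expected move is a 3.8-fold higher number from compound 2 to compound 3 (0.59 log units; beyond the scatter) upward, beyond the scatter. For compound 3 the estimated value is 5 ug/mL with an expected range from 1.8 ug/mL to 14 ug/mL in this assay here.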

Compound 3, half-maximal cytotoxic concentration: 2.3 ug/mL
Compound 3: the middle estimate sits 2.2-fold (0.34 log units) above what was measured, and the stated range covers the measured number.
By their numbers in this assay, from the lowest: compounds 2 and 3 (each within the scatter of the next); then compound 1.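

In this assay, cyclopentyl in place of cyclopropyl on a nitrogen on an aromatic ring gives a 1.8-fold higher number from compound 2 to compound 3 (0.25 log units; within the scatter) and so does not separate the two compounds at this position. Going by these compounds alone, with cyclopentylamino held constant, fluoro in place of hydrogen on an aromatic carbon gives a 4.3-fold lower number from compound 1 to compound 3 (0.64 log units; beyond the scatter) and is the only step here beyond the scatter. Nothing available explains either step. The compounds shown leave open whether the fluoro step also holds with cyclopropylamino. They also leave open how a longer chain such as n-butyl on that nitrogen, or chloro in place of fluoro, would read in this assay here.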